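The source may report more compounds than this note shows. Statements on the series, on what has been measured and on what is new or still open speak of the compounds shown alone.

Working notes on the series

Compound 1 `CCCCC[Se]c1nc(NCc2ccccc2)c2ccccc2n1` carries a pentyl group on selenium; its parent compound 2 `[SeH]c1nc(NCc2ccccc2)c2ccccc2n1` has hydrogen there. In a functional assay on HT-29 cells (Homo sapiens) for cytotoxicity, read by MTT assay, with a stated time of 72 h (a higher number here means a weaker inhibitor of growth, a lower number a stronger inhibitor of growth), compound 1 gives 72700 nM, and compound 2 gives 62200 nM. The change between them, (pentyl in place of hydrogen on a selenium), gives a 1.2-fold higher number from compound 2 to compound 1 (0.07 log units; within the scatter). Compound 3 `Nc1nc([SeH])nc2ncccc12` sits on a different core; the difference between the two cores is not broken down here. In this assay compound 3 gives 36300 nM, and its values against compound 2 and compound 1 lie within the usual scatter, so no order among the three is claimed.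

Compound 4 `CCCCC[Se]c1nc(N)c2cccnc2n1` is the pentyl analogue of compound 3. The change, (pentyl in place of hydrogen on a selenium), is the same as that from compound 2 to compound 1, the place line reading alike in both cases. Because a 1.2-fold higher number from compound 2 to compound 1 (0.07 log units; within the scatter) was within the scatter, the step from compound 3 to compound 4 is expected to be small as well, estimated as a 1.2-fold higher number from compound 3 to compound 4 (0.06 log units; within the scatter). For compound 4 the expected value in this assay is 42000 nM. Compound 4 is estimated to fall between 15000 nM and 110000 nM. Going by the values given here, this rests on a single prior instance of the change and on only three measured compounds.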

Compound 4, concentration for 50% growth inhibition: 5910 nM
Compound 4: the middle estimate sits 7.1-fold (0.85 log units) above what was measured, and the stated range ends above it.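

In this assay pentyl in place of hydrogen on a selenium gives a 6.1-fold lower number from compound 3 to compound 4 (0.79 log units; beyond the scatter) and so does not carry over unchanged from the core of compound 2 to the core of compound 3. The size of the step depends on the core in these two pairs, the only instances shown, and the two steps differ: the same change on two cores in this assay, a 1.2-fold higher number (0.07 log units; within the scatter) from compound 2 to compound 1 and a 6.1-fold lower number (0.79 log units; beyond the scatter) from compound 3 to compound 4, 7.2-fold (0.86 log units) apart, beyond the scatter of two such steps

What this does not show is which feature of the two cores goes with the difference, as the difference between the cores is not broken down, or whether pentyl would lower the number on any further core.

The compounds shown leave open whether a shorter chain such as ethyl or a longer chain such as octyl on the selenium would give a step like that to compound 4 on the same core. Also open, as far as these compounds go, is whether a carboxylic acid or an amine carried on the chain would keep that step, and whether either would behave differently on the core of compound 1.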